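Extending the chain: compound 2 to compound 3

The source may hold more compounds than are shown below. What is called first, only, known or untested is meant among the compounds shown, and "the series" means these compounds.

In a functional assay on Huh-7 cells (Homo sapiens) for cytotoxicity, read by MTT assay, with a stated time of 72 h (a higher number here means that more compound is tolerated, a lower number that less compound is tolerated), compound 1 (`CCCS(=O)(=O)N1CCC2(CC1)OOC(C)(C)OO2`) gives > 100 ug/mL as a limit and not a number. Compound 2 (`CCCS(=O)(=O)N1CCC2(CC1)OOC(C)(CC)OO2`) gives > 100 ug/mL and this too is a limit and not a number. Among the compounds with values here, the series therefore holds no exact value so far, and the limit of > 100 ug/mL in this assay, at which 2 of the 2 values shown sit, describes all of the data.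

Compound 3 (`CCCC1(C)OOC2(CCN(S(=O)(=O)CCC)CC2)OO1`) differs from compound 2 by methyl in place of hydrogen on a saturated chain carbon, two bonds along the chain from a saturated ring carbon and this is methyl in place of hydrogen on a saturated chain carbon, two bonds along the chain from a saturated ring carbon. The same difference can be read as ethyl to propyl.

Within the data shown here, the one measured step that bears on it is a step that the two limits leave unreadable from compound 1 to compound 2 and it also places methyl on a saturated chain carbon. Its size cannot be read, so it offers no direction and no magnitude. No step beyond the usual scatter is therefore expected in this assay and another limit is the likeliest report. The estimate amounts to an expected step that the limit leaves unreadable from compound 2 to compound 3 without any firm direction. Compound 3 is estimated at 130 ug/mL with an expected range of 70 ug/mL to 260 ug/mL in this assay if a number is reported.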

Compound 3, half-maximal cytotoxic concentration: > 100 ug/mL
Compound 3 was reported as a limit; the forecaster's own chance of this, stated with the estimate: 80%; the middle value does not contradict the limit.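

No step can be read among compound 1, compound 2 and compound 3, because all three sit at one limit and not at a number: the limit of > 100 ug/mL in this assay, at which 3 of the 3 values shown sit.

The compounds shown leave open the concentration at which any of them turns cytotoxic in this assay, and whether extending the chain from methyl through ethyl to propyl changes it at all.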